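Working notes: from compound 1 to compound 3

The source may hold more compounds than are shown below. What is called first, only, known or untested is meant among the compounds shown, and "the series" means these compounds.

Measured so far in a functional assay on the whole organism for inhibition, with Mythimna separata as the target, with a stated time of 5 days; a higher number here means that more compound is needed for the effect, a lower number that less compound is needed:
- compound 1 `CC(C)(C)n1ncc(OCc2nnc(-c3cc(F)c(Cl)cc3Cl)s2)c(Cl)c1=O`: 67.1 ug/mL
- compound 2 `CC(C)(C)n1ncc(OCc2nnc(-c3ccc(Cl)cc3F)o2)c(Cl)c1=O`: 10.4 ug/mL

Of these two numbers, compound 1 has the higher at 67.1 ug/mL, so more of it is needed for the effect. Compound 2 stands lower at 10.4 ug/mL, a gap beyond the usual scatter.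

Next is compound 3 `CC(C)(C)n1ncc(OCc2nnc(-c3ccc(F)cc3)s2)c(Cl)c1=O`, which carries 4-fluorophenyl in place of 2,4-dichloro-5-fluorophenyl on an aromatic carbon. Going by the values given here, no measured pair isolates this change, so the expectation rests on very little. With compound 1 at the high end of the two numbers, a modest move to a lower number is expected, only slightly beyond the scatter. The estimated change is a 2.4-fold lower number from compound 1 to compound 3 (0.38 log units; beyond the scatter). For compound 3 the expected value is 28 ug/mL, with an estimated range of 8 ug/mL to 100 ug/mL.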

Compound 3, half-maximal effective concentration: 21.5 ug/mL
Compound 3: the middle estimate sits 1.3-fold (0.11 log units) above what was measured; low and high end bracket the measured number.
By their numbers in this assay, from the lowest: compound 2; then compound 3; then compound 1.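

In this assay, going by these compounds alone, this is the first direct reading at the aryl position on the five-membered ring with 2 nitrogen and 1 sulfur: 4-fluorophenyl in place of 2,4-dichloro-5-fluorophenyl gives a 3.1-fold lower number from compound 1 to compound 3 (0.49 log units; beyond the scatter). The heavier halogen pattern of compound 1 is therefore not required for the effect on this core, and the smaller group does at least as well, with a modest step beyond the scatter. Both chlorines leave and the fluorine pattern changes in this single step, so no one atom can be credited, and nothing on hand explains the step.

Open, as far as these compounds go, is how much of the step belongs to each chlorine and how much to the fluorine. Also open, from the compounds shown here alone, is where a plain phenyl, or a phenyl carrying a methoxy group or an amine, would fall on this core.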